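This account rests on a few compounds, and the source may have more. Where it says the series, first, only, none or still open, it means among the compounds named here.

Of the compounds shown here, three sharing one core have so far been measured in a functional assay on A549 cells (Homo sapiens) for inhibition, read by sulforhodamine B assay, with a stated time of 72 h; on this read-out higher numbers stand for weaker inhibition and lower numbers for stronger inhibition. Compound 1 `CC1CN(C(=O)c2c(N)sc(-c3ccc(Cl)cc3)c2-c2ccc(Cl)cc2)CCN1` gives 4930 nM, the highest of the three numbers. Compound 2 `Nc1sc(-c2ccc(Cl)cc2)c(-c2ccc(Cl)cc2)c1C(=O)NC1CCC(O)CC1` gives 250 nM, and compound 3 `Nc1sc(-c2ccc(Cl)cc2)c(-c2ccc(Cl)cc2)c1C(=O)NC1CC1` gives 1950 nM. The step of a 20-fold lower number from compound 1 to compound 2 (1.29 log units; beyond the scatter) is large and the step of a 2.5-fold lower number from compound 1 to compound 3 (0.40 log units; beyond the scatter) is modest, so both changes at the carbonyl carbon of compound 1 lowered the number, the (4-hydroxycyclohexyl)amino group more than the cyclopropylamino group, as a 7.8-fold higher number from compound 2 to compound 3 (0.89 log units; beyond the scatter) also shows. Compound 4 `COC(=O)c1c(N)sc(-c2ccc(Cl)cc2)c1-c1ccc(Cl)cc1` is not yet measured; it differs from compound 1 by methoxy in place of 3-methylpiperazin-1-yl on a carbonyl carbon. Both measured steps from compound 1 bear on it, since each removes the 3-methylpiperazin-1-yl group, and each lowered the number. Within the data shown here, no measured compound carries a methoxy on that carbon, so the size of the step is open. A modest lowering is therefore expected, closer to the scale of compound 3 than of compound 2. Compound 4 is estimated at 2000 nM, between 500 nM and 8000 nM, an expected step of a 2.5-fold lower number from compound 1 to compound 4 (0.39 log units; beyond the scatter).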

Compound 4, half-maximal inhibitory concentration: 5040 nM
Estimate against measurement, compound 4: 2.5-fold (0.40 log units) below; low and high end bracket the measured number.
By their numbers in this assay, from the lowest: compound 2; then compound 3; then compounds 1 and 4 (each within the scatter of the next).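

In this assay, the step of a 1.0-fold higher number from compound 1 to compound 4 (0.01 log units; within the scatter) shows that exchanging 3-methylpiperazin-1-yl for methoxy on this carbonyl carbon gives no difference beyond the scatter, so removing the 3-methylpiperazin-1-yl group does not by itself account for the lower numbers seen earlier. Those lower numbers instead go with the cyclopropylamino and (4-hydroxycyclohexyl)amino groups, as the step of a 2.6-fold higher number from compound 3 to compound 4 (0.41 log units; beyond the scatter) and the larger step of a 20-fold higher number from compound 2 to compound 4 (1.30 log units; beyond the scatter) show, whereas compound 1, which also joins this carbon through nitrogen, goes against any rule based on that atom alone. No evidence is available on what lies behind these differences.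

The compounds shown leave open how a plain cyclohexylamino group would compare with the (4-hydroxycyclohexyl)amino group of compound 2, which would separate the contribution of the hydroxy group. They also leave open where a carboxylic acid on this carbon would fall.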